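Hexylamino at the ring carbon of compound 3

The source may hold more compounds than are shown below. What is called first, only, known or untested is meant among the compounds shown, and "the series" means these compounds.

Three compounds of the shared core have numbers in an in vitro assay on HEK-tsA201 cells for antagonist activity at Neuronal acetylcholine receptor; alpha4/beta2 (Homo sapiens), read by fluorescence and calcium flux; a higher number here means a weaker inhibitor, a lower number a stronger inhibitor. Compound 1 `C#CCOc1ccc(C(=O)Nc2cccc(C)n2)cc1` gives 19400 nM; compound 2 `C=CCOc1ccc(C(=O)Nc2cccc(CC)n2)cc1` gives 20500 nM; compound 3 `CCCOc1ccc(C(=O)Nc2cccc(CC)n2)cc1` gives 37600 nM. Compound 3 has the highest of the three numbers, but its nearest neighbour compound 2 and its furthest neighbour compound 1 both sit within the scatter of it, so no order among the three can be read. Among the measured compounds shown here, the one single-point step in the set, a 1.8-fold higher number from compound 2 to compound 3 (0.26 log units; within the scatter), is within the scatter and concerns the chain on the ether oxygen, not the ring carbon.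

Compound 4 `CCCCCCNc1cccc(NC(=O)c2ccc(OCCC)cc2)n1` differs from compound 3 by hexylamino in place of ethyl on an aromatic carbon. For the measured compounds named here, no measured step touches this ring carbon, and no measured compound carries a group with a hydrogen-bond donor or acceptor there; the only measured step, from compound 2 to compound 3, is a change elsewhere and is flat. There is therefore no ground to expect a step beyond the scatter in either direction in this assay, and the uncertainty is wide.

For compound 4 the estimate in this assay is 30000 nM, with a range from 8000 nM to 110000 nM, which means an expected step of a 1.3-fold lower number from compound 3 to compound 4 (0.10 log units; within the scatter).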

Compound 4, half-maximal inhibitory concentration: > 100000 nM
Compound 4: no number, only a limit; the forecaster's own chance of this, stated with the estimate: 25%; middle value at least 3.3-fold (0.52 log units) away from the limit.
By their numbers in this assay, from the lowest: compounds 1, 2 and 3 (each within the scatter of the next). At a limit, above all of these: compound 4.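

Compound 4 has no number in this assay, only a limit: the limit of > 100000 nM in this assay, at which 1 of the 4 values shown sits. Against compound 3, hexylamino in place of ethyl on the aromatic carbon next to the ring nitrogen gives an at least 2.6-fold higher number from compound 3 to compound 4 (0.42 log units; beyond the scatter), the first step in the series at this position and the only one shown that lies beyond the scatter. This position is therefore not indifferent to what it carries: the change on the ether oxygen, a 1.8-fold higher number from compound 2 to compound 3 (0.26 log units; within the scatter), left the number within the scatter, whereas this exchange, which adds a longer chain together with an amino nitrogen and a hydrogen-bond donor and acceptor, moves it upward by an amount known only as a lower bound.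

Chain length and the amino nitrogen enter together here, and the compounds shown do not separate them: a plain hexyl chain, or a short amine such as methylamino or a free amino group on the same carbon, would pull the two apart. Going by these compounds, whether any group on this carbon can give a lower number than the ethyl of compound 3 also remains open.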